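Fluoro for methyl beside the acid in compound 4

This account rests on a few compounds, and the source may have more. Where it says the series, first, only, none or still open, it means among the compounds named here.

Of the compounds shown here, three sharing one core have been measured in an assay for positive allosteric modulation of metabotropic glutamate receptor 3 (Rattus norvegicus); on this read-out lower numbers stand for an effect already at smaller amounts and higher numbers for an effect only at larger amounts of compound. Compound 1 `Cc1c(OC[C@@H](C)COc2ccc(F)c(C(=O)O)c2)ccc(C(=O)CC(C)(C)C)c1O` gives 1180 nM, compound 2 `Cc1c(OC[C@@H](C)COc2cc(C(=O)O)ccc2F)ccc(C(=O)CC(C)(C)C)c1O` gives 3950 nM, and compound 3 `Cc1cc(OC[C@H](C)COc2ccc(C(=O)CC(C)(C)C)c(O)c2C)ccc1C(=O)O` gives 1350 nM. On these numbers compound 3 stands second highest of three: its nearest neighbour is compound 1, a gap that lies within the scatter, while compound 2 stands furthest away, as the step of a 2.9-fold lower number from compound 2 to compound 3 (0.47 log units; beyond the scatter) shows.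

Compound 4 `Cc1c(OC[C@@H](C)COc2ccc(C(=O)O)c(F)c2)ccc(C(=O)CC(C)(C)C)c1O` differs from compound 3 by fluoro in place of methyl on an aromatic carbon, on an aromatic carbon ortho to a carboxy group and meta to a large group. The measured steps all concern the substitution pattern of this same aryl ring: a 3.3-fold higher number from compound 1 to compound 2 (0.52 log units; beyond the scatter) and a 2.9-fold lower number from compound 2 to compound 3 (0.47 log units; beyond the scatter) were modest, and a 1.1-fold higher number from compound 1 to compound 3 (0.06 log units; within the scatter) fell within the scatter. None exchanges methyl for fluoro directly, so the author expects for compound 4 a change that is small, at most modest, with no clear direction, in this assay, namely a 1.1-fold higher number from compound 3 to compound 4 (0.05 log units; within the scatter). The estimated value for compound 4 is 1500 nM, with a range from 600 nM to 4000 nM.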

Compound 4, half-maximal effective concentration: 1090 nM
Beside the measured number, compound 4's estimate is 1.4-fold (0.14 log units) above it; the range from low to high includes it.
By their numbers in this assay, from the lowest: compounds 4, 1 and 3 (each within the scatter of the next); then compound 2.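

In this assay, the one direct exchange of methyl for fluoro shown, on an aromatic carbon ortho to a carboxy group, gives two compounds that cannot be told apart (a 1.2-fold lower number from compound 3 to compound 4 (0.09 log units; within the scatter)). The 4-carboxy-3-fluorophenyl group likewise cannot be told apart from the 3-carboxy-4-fluorophenyl group (a 1.1-fold lower number from compound 1 to compound 4 (0.03 log units; within the scatter)), yet it stands clear of the 5-carboxy-2-fluorophenyl group (a 3.6-fold lower number from compound 2 to compound 4 (0.56 log units; beyond the scatter)), so among the three fluoro acids the difference lies with the 5-carboxy-2-fluorophenyl pattern alone. Nothing available bears on why the numbers fall this way.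

On these data alone, whether a chloro or a methoxy group on this same aromatic carbon would also stay within the scatter of methyl and fluoro remains open. So does whether a primary amide or a tetrazole in place of the carboxy group would keep these numbers.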